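The source may hold more compounds than are shown below. What is called first, only, known or untested is meant among the compounds shown, and "the series" means these compounds.

Of the compounds shown here, three sharing one core have been measured, and a fourth awaits its number. Compound 1 `CC(C)c1ccc(C(=O)NC(=O)c2ccccc2O)cc1` carries an isopropyl group on its outer ring; in an ADME assay on L6 cells (Rattus norvegicus) for cytotoxicity, read by resazurin assay, with a stated time of 72 h (on this read-out lower numbers stand for stronger inhibition and higher numbers for weaker inhibition), compound 1 gives 19 ug/mL. Compound 2 `CC(C)(C)c1ccc(C(=O)NC(=O)c2ccccc2O)cc1` differs from compound 1 by methyl in place of hydrogen on a saturated chain carbon bound to an aromatic carbon and two saturated chain carbons; compound 2 gives 2.3 ug/mL, so that the number drops an 8.3-fold lower number from compound 1 to compound 2 (0.92 log units; beyond the scatter). Compound 3 `COc1ccc(C(=O)NC(=O)c2ccccc2O)cc1` differs from compound 1 by methoxy in place of isopropyl on an aromatic carbon; compound 3 gives 39 ug/mL, a step of a 2.1-fold higher number from compound 1 to compound 3 (0.31 log units; beyond the scatter), and it stands a 17-fold higher number from compound 2 to compound 3 (1.23 log units; beyond the scatter) from compound 2.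

Compound 4 `CCOc1ccc(C(=O)NC(=O)c2ccccc2O)cc1` has not yet been measured in this assay. It differs from compound 3 by methyl in place of hydrogen on a saturated chain carbon bound to an oxygen on an aromatic ring. Going by the values given here, this is the same kind of change as the one from compound 1 to compound 2, but not the same change: there the added methyl sat on a saturated chain carbon bound to an aromatic carbon and two saturated chain carbons, whereas here it sits on a saturated chain carbon bound to an oxygen on an aromatic ring.

Only one earlier example of this kind of change exists among these compounds, so the expectation rests on it alone and is held loosely. The step from compound 1 to compound 2 was beyond the usual scatter, so a lower number for compound 4 than for compound 3 is expected, though a smaller step of about a 2.0-fold lower number from compound 3 to compound 4 (0.29 log units; within the scatter) seems more likely, given the different surroundings. Compound 4 is therefore estimated to give 20 ug/mL in this assay, expected to lie between 7 ug/mL and 50 ug/mL.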

Compound 4, half-maximal inhibitory concentration: 17 ug/mL
Compound 4: middle estimate off by 1.2-fold (0.07 log units), on the high side; low and high end bracket the measured number.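

In this assay the added methyl moved the number the same way both times, and the new case gives a 2.3-fold lower number from compound 3 to compound 4 (0.36 log units; beyond the scatter). The direction of the change therefore carried from one core to the other, but its size did not: the same change on two cores in this assay, an 8.3-fold lower number (0.92 log units; beyond the scatter) from compound 1 to compound 2 and a 2.3-fold lower number (0.36 log units; beyond the scatter) from compound 3 to compound 4, 3.6-fold (0.56 log units) apart, beyond the scatter of two such steps. Two examples cannot explain that difference or set a rule for a third case, and swapping groups outright gives a mixed picture: ethoxy stays well apart from tert-butyl, with a 7.4-fold higher number from compound 2 to compound 4 (0.87 log units; beyond the scatter), while a 1.1-fold lower number from compound 1 to compound 4 (0.05 log units; within the scatter) lies within the usual scatter, so ethoxy and isopropyl cannot be told apart here.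

The compounds shown leave open whether a longer chain, such as propoxy in place of the ethoxy, would lower the number again or whether the trend stops at ethoxy. Going by these compounds alone, they also leave open how quite different groups, such as an amine or a carboxylic acid in that same place, would behave, so the series so far covers only a narrow range of small carbon and ether groups.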